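Hydroxyphenyl in place of fluorophenyl on the shared core

A few compounds are considered here, and "the series" means these few. Any claim that something is new, unique, unknown or untested is made for them only; others in the source may bear on it.

Measured compounds:
compound 1 `CCCCCCCCS(=O)(=O)Nc1cc(-c2ccc(CCCC)cc2)ccc1C(=O)O` — 15700 nM
compound 2 `CCCCCCCCS(=O)(=O)Nc1cc(-c2ccccc2OC)ccc1C(=O)O` — 16100 nM
compound 3 `CCCCCCCCS(=O)(=O)Nc1cc(-c2cccc(F)c2)ccc1C(=O)O` — 32600 nM

The three compounds share one core and differ only in the aryl group attached to it. In an assay on mitochondria (strain BALB/c) for inhibition of glycerol-3-phosphate acyltransferase 1, mitochondrial (Mus musculus), read by scintillation counting, with a stated time of 10 min (on this read-out lower numbers stand for stronger inhibition and higher numbers for weaker inhibition), compound 3 gives the highest of the three numbers. Its nearest neighbour is compound 2, reached by a 2.0-fold higher number from compound 2 to compound 3 (0.31 log units; beyond the scatter); the furthest is compound 1, reached by a 2.1-fold higher number from compound 1 to compound 3 (0.32 log units; beyond the scatter). Compound 1 and compound 2 lie within the scatter of each other, as shown by a 1.0-fold higher number from compound 1 to compound 2 (0.01 log units; within the scatter).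

Compound 4 `CCCCCCCCS(=O)(=O)Nc1cc(-c2ccccc2O)ccc1C(=O)O` has not yet been measured. Relative to compound 3, the change is 2-hydroxyphenyl in place of 3-fluorophenyl on an aromatic carbon. Among the measured compounds shown here, no measured step exchanges a fluorophenyl for a hydroxyphenyl, so the nearest guide is the step between compound 2 and compound 3, where a 2-methoxyphenyl stood in place of the 3-fluorophenyl and the number was lower by a 2.0-fold higher number from compound 2 to compound 3 (0.31 log units; beyond the scatter) read in reverse. The 2-hydroxyphenyl of compound 4 resembles the 2-methoxyphenyl of compound 2 more than the 3-fluorophenyl of compound 3, so a modest step toward lower numbers is expected, a 1.8-fold lower number from compound 3 to compound 4 (0.26 log units; within the scatter), though a result within the scatter would not surprise. For compound 4 the expected value in this assay is 18000 nM, with a range from 8000 nM to 45000 nM.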

Compound 4, half-maximal inhibitory concentration: 63100 nM
Beside the measured number, compound 4's estimate is 3.5-fold (0.54 log units) below it; measured number outside the range, above it.
By their numbers in this assay, from the lowest: compounds 1 and 2 (each within the scatter of the next); then compounds 3 and 4 (each within the scatter of the next).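

While a step of a 1.0-fold higher number from compound 1 to compound 2 (0.01 log units; within the scatter) left the 2-methoxyphenyl and 4-butylphenyl groups reading alike in this assay, the new compound shows that this aryl position is not indifferent to every change: hydrogen in place of methyl on the oxygen gives a 3.9-fold higher number from compound 2 to compound 4 (0.59 log units; beyond the scatter) and so moves the number beyond the scatter. The 2-hydroxyphenyl group in place of 4-butylphenyl gives a step of similar size, a 4.0-fold higher number from compound 1 to compound 4 (0.60 log units; beyond the scatter), whereas in place of 3-fluorophenyl it gives only a 1.9-fold higher number from compound 3 to compound 4 (0.29 log units; within the scatter), so compound 3 and compound 4 cannot be told apart on this read-out. Nothing given here accounts for what the free hydroxy group does at this position.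

The compounds shown leave open whether the step seen on removing the methyl belongs to the hydroxy group itself or would recur with an amine on the same aryl ring. They also leave open whether a longer ether chain on that oxygen would keep the number of compound 2 or shift it further.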